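Amide nitrogen variation, compound 3 to compound 4

The source may report more compounds than this note shows. Statements on the series, on what has been measured and on what is new or still open speak of the compounds shown alone.

Compound 1 `CCC(C)NC(=O)/C=C/c1c(/C=C/c2ccc(OC)cc2)cc(OC)cc1OC` gives 4380 nM in a functional assay on B16-F10 cells (Mus musculus) for inhibition, read by MTT assay, with a stated time of 48 h; on this read-out higher numbers stand for weaker inhibition and lower numbers for stronger inhibition. Compound 2 `CCCCCCCCNC(=O)/C=C/c1c(/C=C/c2ccc(OC)cc2)cc(OC)cc1OC` gives 8060 nM in this assay, and compound 3 `COc1ccc(/C=C/c2cc(OC)cc(OC)c2/C=C/C(=O)N2CCCC2)cc1` gives 9280 nM, the highest of the three numbers. The measured steps are a 1.8-fold higher number from compound 1 to compound 2 (0.26 log units; within the scatter), a 2.1-fold higher number from compound 1 to compound 3 (0.33 log units; beyond the scatter) and a 1.2-fold higher number from compound 2 to compound 3 (0.06 log units; within the scatter). Compound 4 `C#CCNC(=O)/C=C/c1c(/C=C/c2ccc(OC)cc2)cc(OC)cc1OC` differs from compound 3 by propargylamino in place of pyrrolidin-1-yl on a carbonyl carbon. The relevant precedents are the two exchanges of an amino group with one hydrogen-bond donor for pyrrolidin-1-yl: from compound 1 a modest rise, from compound 2 a change within the scatter. Going back to a secondary amide is expected to lower the number in this assay only modestly, a 1.7-fold lower number from compound 3 to compound 4 (0.23 log units; within the scatter). Compound 4 is expected at 5500 nM, within 2500 nM to 12000 nM.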

Compound 4, half-maximal inhibitory concentration: 8280 nM
For compound 4 the middle estimate is 1.5-fold (0.18 log units) below the measured one; measured number inside the range.
By their numbers in this assay, from the lowest: compounds 1, 2, 4 and 3 (each within the scatter of the next, the first and the last beyond it).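

In this assay propargylamino in place of pyrrolidin-1-yl on the carbonyl carbon gives a step within the scatter (a 1.1-fold lower number from compound 3 to compound 4 (0.05 log units; within the scatter)), so the hydrogen-bond donor that enters does not separate these two amides. The propargyl amide also stays within the scatter of both the octyl amide (a 1.0-fold higher number from compound 2 to compound 4 (0.01 log units; within the scatter)) and the sec-butyl amide (a 1.9-fold higher number from compound 1 to compound 4 (0.28 log units; within the scatter)). No measurement at hand accounts for these values.

Open, from the compounds shown here alone, is whether a 2-aminoethyl or carboxymethyl group on the amide nitrogen, or morpholin-4-yl on the carbonyl carbon, would fall outside this range.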